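The compounds below may be only part of what the source reports. "The series", "measured", "known", "first", "only" and "open" are said of these compounds alone.

Compound 3 `O=C(/C=C/c1ccc2c(c1)B(O)OC2)c1ccccc1F` gives the lowest number of the three measured compounds in a functional assay on HCT-116 cells (Homo sapiens) for cytotoxicity, read by MTT assay, with a stated time of 48 h (on this read-out lower numbers stand for stronger inhibition and higher numbers for weaker inhibition), where compound 3 gives 4200 nM. Its nearest neighbour is compound 1 `O=C(/C=C/c1ccc2c(c1)B(O)OC2)c1ccccc1`, which in this assay gives 6100 nM; the step of a 1.5-fold lower number from compound 1 to compound 3 (0.16 log units; within the scatter) stays within the scatter. Compound 2 `O=C(/C=C/c1ccc2c(c1)B(O)OC2)c1ccc(Br)cc1` gives 9900 nM, and the step of a 2.4-fold lower number from compound 2 to compound 3 (0.37 log units; beyond the scatter) is the only one beyond the scatter. Compound 4 `O=C(/C=C/c1ccc2c(c1)B(O)OC2)c1cccc(F)c1` differs from compound 3 by 3-fluorophenyl in place of 2-fluorophenyl on a carbonyl carbon. Among the compounds with values here, no measured step moves a fluorine around the ring; the step of a 1.5-fold lower number from compound 1 to compound 3 (0.16 log units; within the scatter) shows that adding fluoro in place of hydrogen changed little. Accordingly no step beyond the scatter is expected, and the estimated step of a 1.1-fold higher number from compound 3 to compound 4 (0.03 log units; within the scatter) leaves compound 4 at an expected 4500 nM, within a range from 2000 nM to 10000 nM.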

Compound 4, half-maximal inhibitory concentration: 6700 nM
Compound 4: the middle estimate sits 1.5-fold (0.17 log units) below what was measured, within the range that was stated.
By their numbers in this assay, from the lowest: compounds 3, 1, 4 and 2 (each within the scatter of the next, the first and the last beyond it).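

Moving the fluorine, with 3-fluorophenyl in place of 2-fluorophenyl on a carbonyl carbon, gives in this assay a 1.6-fold higher number from compound 3 to compound 4 (0.20 log units; within the scatter), so fluorine placement has no clear effect across these two groups. Fluoro in place of hydrogen in this new placement gives a 1.1-fold higher number from compound 1 to compound 4 (0.04 log units; within the scatter), and 3-fluorophenyl in place of 4-bromophenyl gives a 1.5-fold lower number from compound 2 to compound 4 (0.17 log units; within the scatter), so every new step stays small. No measurement shown explains these numbers. As far as these compounds go, whether an aminophenyl or a carboxyphenyl group on that carbonyl carbon would move the number beyond the scatter remains open.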